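A third methoxy on the aromatic ring of compound 2

The source may report more compounds than this note shows. Statements on the series, on what has been measured and on what is new or still open speak of the compounds shown alone.

Measured so far:
compound 1 `COc1ccc(/C=C/C2CC=CC(=O)O2)cc1`: 20.6 uM
compound 2 `COc1ccc(/C=C/C2CC=CC(=O)O2)c(OC)c1`: 4.6 uM

In a functional assay on U-251 cells (Homo sapiens) for inhibition, read by sulforhodamine B assay, with a stated time of 48 h (on this read-out higher numbers stand for weaker inhibition of growth and lower numbers for stronger inhibition of growth), compound 1 gives 20.6 uM and compound 2 gives 4.6 uM. Going by the values given here, compound 2 thus holds the lowest of the two numbers in this assay, with compound 1 as its only neighbour at a higher number; the step of a 4.5-fold lower number from compound 1 to compound 2 (0.65 log units; beyond the scatter) lies beyond the scatter and is the single piece of evidence the series offers.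

Compound 3 `COc1cc(OC)c(OC)cc1/C=C/C1CC=CC(=O)O1` is not yet measured. It differs from compound 2 by methoxy in place of hydrogen on an aromatic carbon.

Among the compounds with values here, the only measured step that bears on this change is a 4.5-fold lower number from compound 1 to compound 2 (0.65 log units; beyond the scatter), which followed the same kind of substitution, a methoxy in place of hydrogen on an aromatic carbon, though at a different position. On that basis a further lowering of the number is expected for compound 3, but with one step as precedent the size is uncertain, and a result within the scatter of compound 2 would not be surprising. The expected step is a 1.8-fold lower number from compound 2 to compound 3 (0.26 log units; within the scatter). Compound 3 is therefore estimated at 2.5 uM, with a range from 0.8 uM to 8 uM.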

Compound 3, concentration for growth inhibition (reported as GI): 11.5 uM
Compound 3: middle estimate off by 4.6-fold (0.66 log units), on the low side; measured number above the stated range.
By their numbers in this assay, from the lowest: compound 2; then compounds 3 and 1 (each within the scatter of the next).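

In this assay, replacing hydrogen with methoxy on the aromatic ring does not act in one direction across the series: a 2.5-fold higher number from compound 2 to compound 3 (0.40 log units; beyond the scatter) runs opposite to a 4.5-fold lower number from compound 1 to compound 2 (0.65 log units; beyond the scatter). The direction of this change therefore depends on where the methoxy enters, and the place filled in compound 3, ortho to a methoxy group, para to a methoxy group and meta to a group of 9 heavy atoms, is one where methoxy weakens growth inhibition relative to hydrogen, a reading that rests on this one pair. Nothing on hand explains the reversal.

The compounds shown leave open whether the higher number belongs to methoxy specifically or would follow any group at this place, and a hydroxyl, a fluorine atom or a longer ethoxy chain there would separate those two readings. Also open, on these data alone, is whether methoxy at this place would give the same direction with either of the two existing methoxy groups absent, as it has been read only with both present.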